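Swapping benzyl for tert-butyl on a nitrone-bearing triazole core

The compounds below may be only part of what the source reports. "The series", "measured", "known", "first", "only" and "open" are said of these compounds alone.

Measured compounds:
- Compound 1 `[O-]/[N+](=C\c1cn(-c2ccc(F)cc2)nn1)Cc1ccccc1`: 9700 nM
- Compound 2 `[O-]/[N+](=C\c1cn(CCC(F)(F)C(F)(F)C(F)(F)C(F)(F)C(F)(F)C(F)(F)F)nn1)Cc1ccccc1`: 12100 nM
- Compound 3 `CC(C)(C)/[N+]([O-])=C/c1cn(-c2ccc(F)cc2)nn1`: 14000 nM

All three were tested in a functional assay on THP-1 cells (Homo sapiens) for inhibition, read by ELISA, with stated times of 2 h and 48 h; on this read-out lower numbers stand for stronger inhibition and higher numbers for weaker inhibition. Compound 1 and compound 3 share a core and differ by one change, (tert-butyl in place of benzyl on a double-bonded nitrogen); the step of a 1.4-fold higher number from compound 1 to compound 3 (0.16 log units; within the scatter) is small. Compound 2 carries a different core, and the difference between the two cores is not broken down here. Compound 4 `CC(C)(C)/[N+]([O-])=C/c1cn(CCC(F)(F)C(F)(F)C(F)(F)C(F)(F)C(F)(F)C(F)(F)F)nn1` is not yet measured; it arises from compound 2 by the same change, (tert-butyl in place of benzyl on a double-bonded nitrogen), at a place described in the same words.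

Among the measured compounds shown here, since the one earlier instance of this change, from compound 1 to compound 3, moved the number only within the scatter, a step of similar size is expected from compound 2 to compound 4, about a 1.3-fold higher number from compound 2 to compound 4 (0.12 log units; within the scatter). Compound 4 is therefore estimated at 16000 nM, likely between 7000 nM and 38000 nM.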

Compound 4, half-maximal inhibitory concentration: 8100 nM
Beside the measured number, compound 4's estimate is 2.0-fold (0.30 log units) above it; the range from low to high includes it.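

In this assay, tert-butyl in place of benzyl on a double-bonded nitrogen gives a 1.5-fold lower number from compound 2 to compound 4 (0.17 log units; within the scatter). Neither this step, the earlier one, nor the gap between them stands clear of the scatter: the same change on two cores in this assay, a 1.4-fold higher number (0.16 log units; within the scatter) from compound 1 to compound 3 and a 1.5-fold lower number (0.17 log units; within the scatter) from compound 2 to compound 4, 2.2-fold (0.33 log units) apart, within the scatter of two such steps. The swap therefore makes no clear difference on either core, but two pairs cannot show that this would hold on other cores, or that the two cores truly respond differently.

The compounds shown carry only benzyl or tert-butyl on that nitrogen, so the effect of a longer chain or a carboxylic acid at that place remains open. As far as these compounds go, it also remains open whether any group there would move the number beyond the scatter.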